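A few compounds are considered here, and "the series" means these few. Any claim that something is new, unique, unknown or untested is made for them only; others in the source may bear on it.

Measured so far in a functional assay on DU-145 cells (Homo sapiens) for inhibition, read by trypan blue exclusion, with a stated time of 96 h; on this read-out lower numbers stand for stronger inhibition of growth and higher numbers for weaker inhibition of growth:
- Compound 1 `COc1cc(/C=C(/Sc2ccc(Br)cc2)C(=O)c2ccc(Br)cc2)ccc1O`: 1000 nM
- Compound 2 `O=C(/C(=C\c1ccc(F)cc1C(F)(F)F)SCc1ccc(F)cc1)c1ccc(Br)cc1`: 10000 nM

Of these two compounds, compound 1 has the lower number and so the stronger inhibition of growth, and the gap to compound 2 lies beyond the usual scatter.

Compound 3 `O=C(/C(=C\c1ccc(Br)c(O)c1)Sc1ccc(Br)cc1)c1ccc(Br)cc1` has not yet been measured. It differs from compound 1 as follows: 4-bromo-3-hydroxyphenyl in place of 4-hydroxy-3-methoxyphenyl on a double-bonded chain carbon bound to a double-bonded chain carbon. In words, 4-bromo-3-hydroxyphenyl stands in place of 4-hydroxy-3-methoxyphenyl on a double-bonded chain carbon bound to a double-bonded chain carbon.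

Among the compounds with values here, no measured pair shows what this exchange does, so compound 1 at 1000 nM is the starting point for the expectation. The expected change is small, slightly towards weaker inhibition and within the scatter, as a 1.5-fold higher number from compound 1 to compound 3 (0.18 log units; within the scatter).

Compound 3 is estimated at 1500 nM, with an expected range of 400 nM to 6000 nM.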

Compound 3, concentration for 50% growth inhibition: 1000 nM
Compound 3: the middle estimate sits 1.5-fold (0.18 log units) above what was measured, within the range that was stated.
By their numbers in this assay, from the lowest: compounds 1 and 3 (each within the scatter of the next); then compound 2.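

Putting 4-bromo-3-hydroxyphenyl in place of 4-hydroxy-3-methoxyphenyl on a double-bonded chain carbon bound to a double-bonded chain carbon gives no change at the digits printed from compound 1 to compound 3 (within the scatter) in this assay. Within the data shown here, this is the first pair differing in one place, and it shows that growth inhibition at this position holds through this exchange, even though the entering group has bromine and one hydrogen-bond acceptor and the leaving group has no bromine and two hydrogen-bond acceptors. Nothing available explains why the two groups read alike.

Going by these compounds, both groups carry a hydroxy group, so its role stays open, and an amine or a carboxylic acid in its place would test it. Also open, on these data alone, is whether bromine itself matters, or whether chlorine or a methyl group would serve equally well.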